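The source may hold more compounds than are shown below. What is called first, only, known or untested is meant among the compounds shown, and "the series" means these compounds.

Measured so far:
compound 1 `N#CCC(=O)N/N=C1\C(=O)Nc2ccc(S(=O)(=O)N3CCOCC3)cc21` — 7530 nM
compound 2 `Cc1ccc(/N=C2\C(=O)Nc3ccc(S(=O)(=O)N4CCOCC4)cc32)cc1` — 12800 nM
compound 3 `Cc1ccc(S(=O)(=O)N/N=C2\C(=O)Nc3ccc(S(=O)(=O)N4CCOCC4)cc32)cc1` — 24700 nM

In a functional assay on HepG2 cells (Homo sapiens) for cytotoxicity, read by sulforhodamine B assay, with a stated time of 24 h (on this read-out higher numbers stand for weaker inhibition and lower numbers for stronger inhibition), compound 1 stands at the lowest of the three numbers. The difference to compound 2 is small (a 1.7-fold higher number from compound 1 to compound 2 (0.23 log units; within the scatter)), so these two cannot be ordered; the difference to compound 3 is larger (a 3.3-fold higher number from compound 1 to compound 3 (0.52 log units; beyond the scatter)) and does stand out from the scatter.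

Compound 4 `O=C1Nc2ccc(S(=O)(=O)N3CCOCC3)cc2/C1=N/NS(=O)(=O)c1ccccc1` has not been measured in this assay. It differs from compound 1 in one place: phenylsulfonyl in place of (cyanomethyl)carbonyl on an amine nitrogen

Of the measured steps, the one that bears on this change is a 3.3-fold higher number from compound 1 to compound 3 (0.52 log units; beyond the scatter): there too a (cyanomethyl)carbonyl on the amine nitrogen was exchanged for an arylsulfonyl, the only distinction being the 4-methyl on the ring of compound 3 that compound 4 lacks. The step to compound 2 concerns a different attachment and carries little weight here. The expectation is therefore a step of similar direction and size, a modestly higher number, a 2.7-fold higher number from compound 1 to compound 4 (0.42 log units; beyond the scatter). The estimated value for compound 4 is 20000 nM, within a range of 9000 nM to 45000 nM.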

Compound 4, half-maximal inhibitory concentration: 23900 nM
Compound 4: middle estimate off by 1.2-fold (0.08 log units), on the low side, and the stated range covers the measured number.
By their numbers in this assay, from the lowest: compounds 1, 2, 4 and 3 (each within the scatter of the next, the first and the last beyond it).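

In this assay, a second arylsulfonyl group on the amine nitrogen gives the same kind of move away from (cyanomethyl)carbonyl (a 3.2-fold higher number from compound 1 to compound 4 (0.50 log units; beyond the scatter)), so the rise seen with compound 3 does not depend on the ring methyl. Removing that methyl from the aromatic carbon leaves no readable difference (a 1.0-fold lower number from compound 3 to compound 4 (0.01 log units; within the scatter)), and (phenylsulfonyl)amino and 4-methylphenyl on the double-bonded nitrogen cannot be ordered (a 1.9-fold higher number from compound 2 to compound 4 (0.27 log units; within the scatter)). Nothing measured here gives a reason for these steps.

On these data alone, it remains open whether a group other than methyl on the phenyl ring, such as an amine or a carboxylic acid, would shift the number from that of compound 4. As far as these compounds go, it is also open whether a plain acetyl or a longer acyl chain without the nitrile would stay as low as compound 1.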